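The source may hold more compounds than are shown below. What is called first, only, known or untested is meant among the compounds shown, and "the series" means these compounds.

Compound 2 `Cc1c(C(=O)/C=C/c2ccc(Cl)c(Cl)c2)[n+]([O-])c2ccccc2[n+]1[O-]` is one of two compounds tested in a functional assay on HSC-4 cells (Homo sapiens) for cytotoxicity, with a stated time of 48 h (on this read-out higher numbers stand for lower toxicity in this test and lower numbers for higher toxicity in this test), where compound 2 gives 15000 nM. Among the measured compounds shown here, its only companion is compound 1 `Cc1c(C(=O)/C=C/c2ccc(Cl)cc2)[n+]([O-])c2ccccc2[n+]1[O-]`, which in this assay gives 19000 nM; the two numbers sit alongside each other, as the step of a 1.3-fold lower number from compound 1 to compound 2 (0.10 log units; within the scatter) shows, which is within the scatter. Compound 3 `Cc1c(C(=O)/C=C/c2ccc(F)cc2)[n+]([O-])c2ccccc2[n+]1[O-]` has not yet been measured. Its difference from compound 2 is 4-fluorophenyl in place of 3,4-dichlorophenyl on a double-bonded chain carbon bound to a double-bonded chain carbon. For the measured compounds named here, the one measured step, from compound 1 to compound 2, changed the same aromatic ring by a single chloro in place of hydrogen and stayed within the scatter, so the measured data give no sign that altering the halogen pattern on this ring moves the number in this assay beyond the scatter. Compound 3 is therefore expected to give about 20000 nM in this assay, with a range of 9000 nM to 45000 nM. The expected step is a 1.3-fold higher number from compound 2 to compound 3 (0.12 log units; within the scatter), a change not expected to exceed the scatter.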

Compound 3, half-maximal cytotoxic concentration: 8100 nM
Beside the measured number, compound 3's estimate is 2.5-fold (0.39 log units) above it; the whole stated range lies above it.
By their numbers in this assay, from the lowest: compounds 3, 2 and 1 (each within the scatter of the next, the first and the last beyond it).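

In this assay, among the compounds shown here, fluoro in place of chloro on an aromatic carbon gives a 2.3-fold lower number from compound 1 to compound 3 (0.37 log units; beyond the scatter) and so is the first step in this small set to pass the scatter, though only modestly, which shows that exchanging one halogen on this ring can shift the number towards higher toxicity in this test. The larger exchange of 3,4-dichlorophenyl for 4-fluorophenyl on a double-bonded chain carbon bound to a double-bonded chain carbon gives a 1.9-fold lower number from compound 2 to compound 3 (0.27 log units; within the scatter) and stays within the scatter, so compound 2 and compound 3 cannot be separated. Nothing measured here gives a reason for the gap between the chloro and fluoro compounds.

The compounds shown leave open what a plain phenyl ring, carrying no halogen, would give at this place. They also leave open whether a ring bearing a methoxy group or an amine would stay in the same range.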